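Swapping the carbamate tail for a thiocarbamate

The source may hold more compounds than are shown below. What is called first, only, known or untested is meant among the compounds shown, and "the series" means these compounds.

Compound 2 `Cc1nc(S(C)(=O)=O)ccc1Oc1ncnc(OC2CCN(C(=O)OC3(C(F)(F)F)CCC3)CC2)c1F`: 14.3 nM
Compound 1 `Cc1nc(S(C)(=O)=O)ccc1Oc1ncnc(OC2CCN(C(=O)O[C@H](C)C(F)(F)F)CC2)c1F`: 9.2 nM

In a functional assay on isolated protein for inhibition of Glucose-dependent insulinotropic receptor (Homo sapiens), read by HTRF and cAMP accumulation (on this read-out lower numbers stand for an effect already at smaller amounts and higher numbers for an effect only at larger amounts of compound), compound 2 gives 14.3 nM, the higher of the two numbers measured, while compound 1 gives 9.2 nM; the step of a 1.6-fold higher number from compound 1 to compound 2 (0.19 log units; within the scatter) is within the scatter. Compound 3 `Cc1nc(S(C)(=O)=O)ccc1Oc1ncnc(OC2CCN(C(=O)SC(C)(C)C)CC2)c1F` differs from compound 2 by a group of 5 heavy atoms (4 carbon, 1 sulfur; no ring) in place of a group of 9 heavy atoms (5 carbon, 1 oxygen, 3 fluorine; one four-membered non-aromatic ring of carbon only), on a carbonyl carbon. Within the data shown here, the only measured step, from compound 1 to compound 2, exchanges one fluorinated group for another at the same carbonyl and barely moves the number; it bears only loosely on the present change, which removes the fluorine atoms altogether. For compound 3 a small shift to a higher number is expected, as a 1.5-fold higher number from compound 2 to compound 3 (0.19 log units; within the scatter), giving an estimate of 22 nM (range 7 nM to 70 nM).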

Compound 3, half-maximal effective concentration: 4.83 nM
For compound 3 the middle estimate is 4.6-fold (0.66 log units) above the measured one; the measured number lies below the stated range.
By their numbers in this assay, from the lowest: compounds 3, 1 and 2 (each within the scatter of the next, the first and the last beyond it).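

In this assay, a group without fluorine or a ring can hold its own on this carbonyl carbon: (tert-butyl)sulfanyl gives a 3.0-fold lower number from compound 2 to compound 3 (0.47 log units; beyond the scatter). Against compound 1, the same group gives a 1.9-fold lower number from compound 1 to compound 3 (0.28 log units; within the scatter), so those two compounds cannot be told apart. Nothing available explains either step.

On these data alone, compound 3 changes the linking atom and the carbon group at once, so the share of the sulfur and the share of the tert-butyl remain unknown. A tert-butoxy group on the same carbonyl carbon would separate the two.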